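A few compounds are considered here, and "the series" means these few. Any claim that something is new, unique, unknown or untested is made for them only; others in the source may bear on it.

Compound 1 `CCC1(CCCCN2CCN(c3cccc(Cl)c3)CC2)C(=O)Nc2ccccc21` is the starting point. In a functional assay on the whole organism (strain NMRI) with Mus musculus as the target, in the forced swim test, with stated times of 30 min, 4 min and 6 min (on this read-out higher numbers stand for an effect only at larger amounts of compound and lower numbers for an effect already at smaller amounts), compound 1 gives only a limit of > 10 mg/kg, so no number is known for it. Its close relative compound 2 `CCC1(CCCCN2CCN(c3ccc(Cl)c(Cl)c3)CC2)C(=O)Nc2ccccc21` likewise gives only a limit in this assay, namely > 10 mg/kg. The step that the two limits leave unreadable from compound 1 to compound 2 therefore cannot be read, since (the limit of > 10 mg/kg in this assay, at which 2 of the 2 values shown sit). The change from compound 1 to compound 3 `O=C1Nc2ccccc2C1CCCCN1CCN(c2cccc(Cl)c2)CC1` is hydrogen in place of ethyl on a saturated ring carbon. Among the compounds with values here, no measured step bears on this change, and the single measured step is itself unreadable, so nothing among the measured compounds indicates a direction or size for the step in this assay; the expectation is that compound 3 stays near the limit region of compound 1. Compound 3 is estimated at 10 mg/kg in this assay, within 3 mg/kg to 30 mg/kg, and the step of a number no higher from compound 1 to compound 3 (the limit leaves the size open) is expected to lie within the scatter.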

Compound 3, minimum effective dose: > 10 mg/kg
Compound 3: only a limit was reported (the forecaster's own chance of this, stated with the estimate: 60%); the middle value lies on the limit itself.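

The step from compound 1 to compound 3 cannot be read, since both compounds give only a limit in this assay: the limit of > 10 mg/kg in this assay, at which 3 of the 3 values shown sit.

The compounds shown leave open whether hydrogen in place of ethyl, or chloro in place of hydrogen, changes the minimum effective dose at all.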